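Anilino in Place of 4-Chlorophenyl on the Shared Core

A few compounds are considered here, and "the series" means these few. Any claim that something is new, unique, unknown or untested is made for them only; others in the source may bear on it.

Measured compounds:
compound 1 `COc1cc(C(=O)c2sc3ccccc3c2-c2ccccc2)cc(OC)c1OC`, 1900 nM
compound 2 `COc1cc(C(=O)c2sc3ccccc3c2-c2ccc(Cl)cc2)cc(OC)c1OC`, 5200 nM
compound 3 `COc1cc(C(=O)c2sc3ccccc3c2-c2ccc(SC)cc2)cc(OC)c1OC`, 3500 nM

In a functional assay on HeLa cells (Homo sapiens) for antiproliferative activity, read by MTT assay, with a stated time of 72 h (a lower number here means a stronger inhibitor, a higher number a weaker inhibitor), compound 2 gives the highest of the three numbers; its step to compound 3 lies within the scatter, while a 2.7-fold higher number from compound 1 to compound 2 (0.44 log units; beyond the scatter) lies beyond it. Compound 4 `COc1cc(C(=O)c2sc3ccccc3c2Nc2ccccc2)cc(OC)c1OC` is not yet measured. It differs from compound 2 as follows: anilino in place of 4-chlorophenyl on an aromatic carbon. Among the compounds with values here, no measured step bears directly on this change; the only nearby hint is that removing chloro, as in a 2.7-fold higher number from compound 1 to compound 2 (0.44 log units; beyond the scatter) read backwards, went with a lower number. Within the data shown here, compound 4 is therefore expected to show a modest step downward, a 1.7-fold lower number from compound 2 to compound 4 (0.24 log units; within the scatter), though the anilino linkage itself has no precedent here. The estimated value for compound 4 is 3000 nM, with a range from 900 nM to 10000 nM.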

Compound 4, half-maximal inhibitory concentration: 2700 nM
The estimate for compound 4 lay 1.1-fold (0.05 log units) above the measured number; the range from low to high includes it.
By their numbers in this assay, from the lowest: compounds 1, 4, 3 and 2 (each within the scatter of the next, the first and the last beyond it).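

In this assay, anilino takes the place of each aryl group on this aromatic carbon with every step within the scatter: a 1.9-fold lower number from compound 2 to compound 4 (0.28 log units; within the scatter), a 1.3-fold lower number from compound 3 to compound 4 (0.11 log units; within the scatter) and a 1.4-fold higher number from compound 1 to compound 4 (0.15 log units; within the scatter). The position therefore tolerates anilino, which brings a hydrogen-bond donor that 4-chlorophenyl lacks, and compound 4 cannot be told apart from any of the other three compounds. Nothing at hand gives a reason for this.

Still open, as far as these compounds go, is whether chloro or methylsulfanyl on the anilino ring would act as it does on the phenyl ring. Also open, from the compounds shown here alone, is how a benzylamino or N-methylanilino group would fare on this carbon.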